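Cytotoxicity in the amide series: mirror image of compound 1

A few compounds are considered here, and "the series" means these few. Any claim that something is new, unique, unknown or untested is made for them only; others in the source may bear on it.

Measured so far:
Compound 1 `CCCNC(=O)[C@H]1CC[C@H](NC(=O)c2cc3sc(Br)cc3n2Cc2ccc(OC)cc2)CC1`, in an ADME assay on HEK-293T cells (Homo sapiens) for cytotoxicity, read by luminescence and CellTiter-Glo, with a stated time of 24 h (on this read-out lower numbers stand for higher toxicity in this test and higher numbers for lower toxicity in this test), compound 1 gives > 100000 nM, which is a limit of the assay and not a number.
Compound 2 `CCCNC(=O)C1CCN(C(=O)c2cc3nc(Br)sc3n2Cc2ccc(OC)cc2)CC1`, in this assay compound 2 gives 46800 nM.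
Compound 3 `CCCNC(=O)[C@@H]1C[C@H]2CCC[C@@H](C1)[C@@H]2NC(=O)c1cc2sc(-c3ccccc3)nc2n1Cc1ccc(OC)cc1`, in this assay compound 3 gives > 100000 nM, again a limit of the assay and not a number.

Compound 1 therefore stands at the limit of > 100000 nM in this assay, at which 2 of the 3 values shown sit, so no number is known for it, only that it reaches the upper edge of the measured window. Compound 2 alone is reported as a number.

The unmeasured compound 4 `CCCNC(=O)[C@H]1CC[C@@H](NC(=O)c2cc3sc(Br)cc3n2Cc2ccc(OC)cc2)CC1` differs from compound 1 as follows: the two compounds have the same atoms and bonds and differ only in configuration as drawn: 2 of 2 stereo elements differ (all stereocentres are inverted: mirror images); a stereocentre at a saturated ring carbon is drawn r in compound 1 and s in compound 4; a stereocentre at a saturated ring carbon is drawn r in compound 1 and s in compound 4. Among the compounds with values here, no pair of measured compounds is separated by a single change, so no measured step gives a scale for this one. Within the data shown here, with compound 1 at the limit and the only other compound differing solely in configuration, the expectation is no step beyond the scatter, and the step from compound 1 to compound 4 is expected as a number no higher from compound 1 to compound 4 (the limit leaves the size open). Compound 4 is estimated at 100000 nM, expected to fall between 50000 nM and 300000 nM, most likely again returned as a limit rather than a number.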

Compound 4, half-maximal cytotoxic concentration: > 100000 nM
Compound 4: no number, only a limit (the forecaster's own chance of this, stated with the estimate: 70%); the middle value sits exactly at the limit.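

Compound 1 and compound 4 both return a limit of the assay and not a number in this assay, so no step can be read between these mirror images. The compounds shown leave open whether inverting both stereocentres changes the half-maximal cytotoxic concentration at all, as no number exists for either compound.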